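From 4-cyanophenyl to 3-cyanophenyl: compound 2 and compound 4

The source may hold more compounds than are shown below. What is called first, only, known or untested is meant among the compounds shown, and "the series" means these compounds.

Measured in a functional assay on MIA PaCa-2 cells (Homo sapiens) for inhibition, read by MTT assay, with a stated time of 72 h, tested at 30 uM; on this read-out higher numbers stand for more inhibition of growth at the one concentration tested and lower numbers for less inhibition of growth:
- compound 1 `C=CCc1cc(O)c(O)c(CN2CCC(C)CC2)c1` gives 91.5%
- compound 2 `C=CCc1ccc(OCc2cn(-c3ccc(C#N)cc3)nn2)c(O)c1` gives 39.3%
- compound 3 `C=CCc1ccc(OCc2cn(-c3cc(OC)c(OC)c(OC)c3)nn2)c(O)c1` gives 41.1%

In this assay compound 2 at 39.3% stands within the scatter of compound 3 at 41.1%. Both sit well beneath compound 1 at 91.5%, a gap beyond the scatter.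

The next compound to be tested is compound 4 `C=CCc1ccc(OCc2cn(-c3cccc(C#N)c3)nn2)c(O)c1`, which has 3-cyanophenyl in place of 4-cyanophenyl on an aromatic nitrogen. Among the compounds with values here, no two measured compounds differ in only one place, so the data offer no direct guide to this change. Compound 3 at 41.1% carries a different group on that same nitrogen and still stays within the scatter of compound 2, which suggests little sensitivity there. No change beyond the scatter is therefore expected, and the estimated step is a number 0.7 percentage points higher from compound 2 to compound 4 (within the scatter). For compound 4 the expected value is 40%, with an estimated range of 27% to 53%.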

Compound 4, percent growth inhibition at one concentration: 26.6%
Beside the measured number, compound 4's estimate is 13.4 percentage points above it; the whole stated range lies above it.
By their numbers in this assay, from the lowest: compound 4; then compounds 2 and 3 (each within the scatter of the next); then compound 1.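

In this assay, within the data shown here, exchanging 4-cyanophenyl for 3-cyanophenyl on the aromatic nitrogen gives a number 12.7 percentage points lower from compound 2 to compound 4 (beyond the scatter), the first step in this set between compounds that differ in one place. Among these compounds, the two groups have the same atoms and the same counts of donors and acceptors, so this aromatic nitrogen substituent is sensitive to how its atoms are joined, which the earlier compounds, with no such pair among them, could not show. Nothing available accounts for the size or direction of this step.

The compounds shown rest on this single pair, so it remains open whether the step reflects a wider trend at this position. Also open, on these data alone, is how a carboxylic acid or an amine would behave in place of the nitrile on this phenyl ring.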